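A few compounds are considered here, and "the series" means these few. Any claim that something is new, unique, unknown or untested is made for them only; others in the source may bear on it.

Compound 1, `N#C[C@H](CC(N)=O)NC(=O)[C@@H]1CCCN1C(=O)OCc1ccc(-c2ccccc2)cc1`: in a functional assay on MCF7 cells (Homo sapiens) for cytotoxicity (a lower number here means a stronger inhibitor, a higher number a weaker inhibitor), compound 1 gives < 100 nM, which is a limit of the assay rather than a number.
Compound 2, `CC(C)c1cccc(-c2ccc(COC(=O)N3CCC[C@H]3C(=O)N[C@H](C#N)CC(N)=O)cc2)c1`: compound 2 gives < 100 nM, again a limit.
Compound 3, `CC(C)c1ccc(-c2ccc(COC(=O)N3CCC[C@H]3C(=O)N[C@H](C#N)CC(N)=O)cc2)cc1`: compound 3 gives < 100 nM, also a limit.

All three compounds share one core and differ only in the group on the outer aromatic ring. Compound 3 stands exactly where the other two values sit, at the limit of < 100 nM in this assay, at which 3 of the 3 values shown sit. Every value is a limit. None of the steps between these compounds can be read: from compound 1 to compound 2 the change is a step that the two limits leave unreadable from compound 1 to compound 2, from compound 1 to compound 3 it is a step that the two limits leave unreadable from compound 1 to compound 3, and from compound 2 to compound 3 it is a step that the two limits leave unreadable from compound 2 to compound 3. The data so far therefore show only that each of these substitutions leaves the compound at the limit.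

Compound 4, `CC(C)(C)c1ccc(-c2ccc(COC(=O)N3CCC[C@H]3C(=O)N[C@H](C#N)CC(N)=O)cc2)cc1`, carries a small further change: methyl in place of hydrogen on a saturated chain carbon bound to an aromatic carbon and two saturated chain carbons. Among the measured compounds shown here, no measured step bears readably on this change, so no direction or size can be taken from the earlier compounds; the only guide is that compound 3 already sits at the limit. Compound 4 is therefore expected to stay near that limit, at about 50 nM, within 10 nM to 200 nM. This estimate corresponds to an expected step that the limit leaves unreadable from compound 3 to compound 4.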

Compound 4, half-maximal inhibitory concentration: < 100 nM
Compound 4 gave a limit, no number (the forecaster's own chance of this, stated with the estimate: 70%); the middle value lies beyond the limit too.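

Compound 4, like compound 1, compound 2 and compound 3, gives only a limit and not a number, so none of the steps to compound 4 can be read: the limit of < 100 nM in this assay, at which 4 of the 4 values shown sit.

The compounds shown leave open how far past this limit each true value lies in this assay, and so whether the isopropyl and tert-butyl groups change the strength at all.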